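Urea to amide reversion in the pyrazole anilide series

This account rests on a few compounds, and the source may have more. Where it says the series, first, only, none or still open, it means among the compounds named here.

Compound 3 `COc1cc(Cl)cc(-c2nn(-c3cccc(NC(=O)Nc4ccc(Cl)c(Cl)c4)c3)cc2-c2ccncc2)c1` gives -5.03% in a functional assay on PC-3 cells (Homo sapiens) for inhibition, read by sulforhodamine B assay, with a stated time of 48 h, tested at 10 uM (on this read-out higher numbers stand for a weaker effect at the one concentration tested and lower numbers for a stronger effect), the lowest of the three numbers recorded. Compound 2 `O=C(Nc1cccc(-n2cc(-c3ccncc3)c(-c3cc(O)cc(Cl)c3)n2)c1)Nc1ccc(Cl)c(Cl)c1` gives -1.66% in this assay, and the two sit within the scatter of each other: a number 3.4 percentage points lower from compound 2 to compound 3 (within the scatter). Going by the values given here, compound 1 `COc1cc(Cl)cc(-c2nn(-c3cccc(NC(=O)c4ccc(Cl)c(Cl)c4)c3)cc2-c2ccncc2)c1` gives 34% in this assay, the only value far from compound 3, and that step, a number 39 percentage points lower from compound 1 to compound 3 (beyond the scatter), is the one that matters here.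

Compound 4 `COc1cc(Cl)cc(-c2nn(-c3cccc(NC(=O)c4cccc(C(F)(F)F)c4)c3)cc2-c2ccncc2)c1` differs from compound 3 at the carbonyl carbon: 3-(trifluoromethyl)phenyl in place of (3,4-dichlorophenyl)amino on a carbonyl carbon. The change undoes the kind of replacement seen between compound 1 and compound 3, though the ring that enters is 3-(trifluoromethyl)phenyl rather than 3,4-dichlorophenyl, so the two steps are not the same pair. The step from compound 1 to compound 3 was large and lowered the number; going the other way at the same position, a rise of comparable size is expected, with the weaker effect that a higher number stands for in this assay.

The expected step is a number 35 percentage points higher from compound 3 to compound 4 (beyond the scatter). Compound 4 is therefore estimated at 30% in this assay, within a range from 5% to 55%.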

Compound 4, a percentage reported as activity, at one concentration (the size of the read-out at that concentration, not a potency): 23.1%
For compound 4 the middle estimate is 6.9 percentage points above the measured one; low and high end bracket the measured number.
By their numbers in this assay, from the lowest: compounds 3 and 2 (each within the scatter of the next); then compound 4; then compound 1.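

At the carbonyl carbon, a second amide now stands apart from the urea: in this assay the exchange of (3,4-dichlorophenyl)amino for 3-(trifluoromethyl)phenyl gives a number 28.1 percentage points higher from compound 3 to compound 4 (beyond the scatter), so the gap seen with compound 1 is not confined to a single aryl group on the amide. The aryl group itself also counts, since the change of 3,4-dichlorophenyl to 3-(trifluoromethyl)phenyl on the amide carbonyl gives a number 10.9 percentage points lower from compound 1 to compound 4 (beyond the scatter). Nothing measured here accounts for either step.

Still open, on these data alone, is whether a urea carrying (3-(trifluoromethyl)phenyl)amino on the carbonyl carbon would track compound 3 or compound 4. Also open, as far as these compounds go, is where a cyclohexyl group or a morpholine on that carbonyl carbon would fall, or a sulfonamide in place of the carbonyl link.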